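Swapping the amine-bearing arm on a shared core

This account rests on a few compounds, and the source may have more. Where it says the series, first, only, none or still open, it means among the compounds named here.

Compound 2 `CCCCCCCCCCc1ccc(-c2noc(-c3cccc(CN)c3)n2)cc1` and compound 1 `CCCCCCCCCCc1ccc(-c2noc([C@@H]3CCC[C@@H](N)C3)n2)cc1` share one core and differ only in the group attached to it. In an assay on HeLa cells for inhibition of sphingosine-1-phosphate transporter SPNS2 (Mus musculus), read by LC-MS, tested at 2 uM (a lower number here means less inhibition, a higher number more inhibition at the concentration tested (going by the name of the read-out)), compound 1 gives 13%, while compound 2 gives 2%; that is a number 11 percentage points lower from compound 1 to compound 2 (beyond the scatter). Among the measured compounds shown here, compound 2 therefore stands lowest of the two numbers measured so far, and its only neighbour, compound 1, lies higher by more than the scatter.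

Compound 3 `CCCCCCCCCCc1ccc(-c2noc(CC(O)CN(C)C)n2)cc1` has not yet been measured. It carries 3-(dimethylamino)-2-hydroxypropyl in place of 3-(aminomethyl)phenyl on an aromatic carbon. For the measured compounds named here, the only step known, a number 11 percentage points lower from compound 1 to compound 2 (beyond the scatter), concerns a different exchange on the same aromatic carbon, so it bears on this one only by showing that changing the amine-bearing group there moved the read-out modestly, and downward. Compound 2 already sits near the floor of the read-out, leaving little room to fall further. Compound 3 is therefore expected to show a number 6 percentage points higher from compound 2 to compound 3 (within the scatter), no step beyond the scatter. The estimate for compound 3 in this assay is 8%, within a range of 0% to 25%.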

Compound 3, a percentage reported as inhibition, at one concentration (the size of the read-out at that concentration, not a potency): 61%
Compound 3: middle estimate off by 53 percentage points, on the low side; measured number outside the range, above it.
By their numbers in this assay, from the lowest: compound 2; then compound 1; then compound 3.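

Compound 3 shows that this aromatic carbon of the shared core is not stuck near the bottom of the scale: in this assay the exchange of 3-(aminomethyl)phenyl for 3-(dimethylamino)-2-hydroxypropyl gives a number 59 percentage points higher from compound 2 to compound 3 (beyond the scatter), and the exchange of 3-aminocyclohexyl for the same chain gives a number 48 percentage points higher from compound 1 to compound 3 (beyond the scatter). The two arms that contain a ring, one aromatic and one not, both stay far under the open chain, so among these three compounds the choice of group at this position matters much more than the earlier step between the two ring arms suggested. No measurement shown here gives a reason for this rise.

The entering chain differs from both ring arms in several ways at once, losing the ring and bringing a hydroxy group and a dimethylamino group, so these compounds cannot say which of these features goes with the higher number. A plain 3-(dimethylamino)propyl chain without the hydroxy group, or the same hydroxy chain ending in a primary amine, would separate those features.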